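The source may hold more compounds than are shown below. What is called first, only, known or untested is meant among the compounds shown, and "the series" means these compounds.

Measured in a functional assay on HEK293 cells for positive allosteric modulation of metabotropic glutamate receptor 5 (Homo sapiens), read by FLIPR and calcium flux; a higher number here means that more compound is needed for the effect, a lower number that less compound is needed:
compound 1 `O=C(COCc1ccccc1)N1CCN(c2ccccc2)CC1`: 7100 nM
compound 2 `O=C(COCc1ccccc1)N1CCN(c2ccc(Cl)cc2Cl)CC1`: 1000 nM
compound 3 `O=C(COCc1ccccc1)N1CCN(c2cc(Cl)ccn2)CC1`: 570 nM

Compound 2 stands second highest of the three numbers, but its nearest neighbour is compound 3, and the gap between them, a 1.8-fold lower number from compound 2 to compound 3 (0.24 log units; within the scatter), lies within the scatter, so the two cannot be ordered. The furthest is compound 1, separated from compound 2 by a 7.1-fold lower number from compound 1 to compound 2 (0.85 log units; beyond the scatter). The remaining measured step, a 12-fold lower number from compound 1 to compound 3 (1.10 log units; beyond the scatter), is also beyond the scatter. All three steps change only the group on the amine nitrogen in the ring; the benzyloxy side of the shared core is identical in every measured compound.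

Compound 4 `O=C(COCc1ncccn1)N1CCN(c2ccc(Cl)cc2Cl)CC1` differs from compound 2 on that untouched side: pyrimidin-2-yl in place of phenyl on a saturated chain carbon bound to an oxygen on a saturated carbon. Among the compounds with values here, no measured step bears on this part of the molecule, so neither the size nor the direction of the step in this assay can be read from the data. The step is expected to be a 1.5-fold higher number from compound 2 to compound 4 (0.18 log units; within the scatter), with a deliberately wide range on either side. Compound 4 is therefore estimated at 1500 nM, within 400 nM to 6000 nM.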

Compound 4, half-maximal effective concentration: 18000 nM
The estimate for compound 4 lay 12-fold (1.08 log units) below the measured number; the whole stated range lies below it.
By their numbers in this assay, from the lowest: compounds 3 and 2 (each within the scatter of the next); then compound 1; then compound 4.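

The benzyloxy side of the shared core, constant in compounds 1 to 3, is not indifferent in this assay: replacing phenyl with pyrimidin-2-yl on a saturated chain carbon bound to an oxygen on a saturated carbon gives an 18-fold higher number from compound 2 to compound 4 (1.26 log units; beyond the scatter), a step that is large and beyond the scatter. The change does not touch the 2,4-dichlorophenyl group on the amine nitrogen, so this single step shows that the number also responds to the group at the far end of the benzyloxy side, and here it moves upward, unlike the measured steps on the amine nitrogen. Both groups are six-membered aromatic rings, but the entering ring carries hetero atoms and hydrogen-bond acceptors, and no available evidence bears on the reason for the step.

Still open, going by these compounds, is whether pyridin-2-yl or a saturated cyclohexyl in this place would give a number nearer that of compound 2 or that of compound 4. Also open, on these data alone, is whether the step would keep its size with the 4-chloropyridin-2-yl group of compound 3 on the amine nitrogen.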